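Notes on replacing chloro with hydroxy in compound 3

The source may report more compounds than this note shows. Statements on the series, on what has been measured and on what is new or still open speak of the compounds shown alone.

In an ADME assay on NHDF cells (Homo sapiens) for cytotoxicity, read by MTT assay, with a stated time of 72 h (a lower number here means a stronger inhibitor, a higher number a weaker inhibitor), compound 1 `COc1cccc(/C=C2\CCC/C(=C\c3ccccc3Br)C2=O)c1OC` gives > 50000 nM, which is a limit of the assay. Compound 2 `COc1ccc(/C=C2\CCC/C(=C\c3cccc(OC)c3OC)C2=O)cc1` gives 43500 nM. Compound 3 `COc1ccc(/C=C2\CCC/C(=C\c3cccc(Cl)c3)C2=O)cc1OC` gives 11900 nM, the lower of the two true numbers in this assay.

Compound 4 `COc1ccc(/C=C2\CCC/C(=C\c3cccc(O)c3)C2=O)cc1OC` carries hydroxy in place of chloro on an aromatic carbon.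

Among the compounds with values here, the sole measured step, an at least 1.1-fold lower number from compound 1 to compound 2 (0.06 log units; that floor lies within the scatter), concerns 4-methoxyphenyl in place of 2-bromophenyl, a different change, so it does not bear directly on this one. On these data alone, no step beyond the scatter is therefore expected, and the direction stays open. The expected step is a 1.2-fold higher number from compound 3 to compound 4 (0.07 log units; within the scatter). For compound 4 the estimated value is 14000 nM, with an expected range of 5000 nM to 40000 nM.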

Compound 4, half-maximal inhibitory concentration: 6800 nM
Compound 4: the middle estimate sits 2.1-fold (0.31 log units) above what was measured, and the stated range covers the measured number.
By their numbers in this assay, from the lowest: compounds 4 and 3 (each within the scatter of the next); then compound 2. At a limit, above all of these: compound 1.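

Going from 3-chlorophenyl to 3-hydroxyphenyl in this assay gives a 1.8-fold lower number from compound 3 to compound 4 (0.24 log units; within the scatter) and so stays within the scatter. On this aromatic carbon, then, the series does not separate hydroxy from chloro, a reading the earlier step, which concerned another change, could not give. Nothing on hand bears on why the two groups read alike.

On these data alone, whether an amine or a carboxylic acid on the same carbon would separate from these two groups stays open. So does whether a longer chain there would move the number beyond the scatter.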